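Side-chain exchange on the urea series: compound 2 to compound 3

A few compounds are considered here, and "the series" means these few. Any claim that something is new, unique, unknown or untested is made for them only; others in the source may bear on it.

Going by the values given here, in a physicochemical assay for lipophilicity, read by HPLC (a higher number here means a more lipophilic compound, a lower number a more polar compound), compound 1 `CC(C)(C)c1ccccc1Oc1ncccc1NC(=O)Nc1ccc(C2(CO)CC2)cc1` gives 4.6 and compound 2 `CN(C)CC(C)(C)COc1ccc(NC(=O)Nc2cccnc2Oc2ccccc2C(C)(C)C)cc1` gives 5.1 as the higher of the only two numbers so far. The next entry is compound 3 `CC(C)CN1CCC(COc2ccc(NC(=O)Nc3cccnc3Oc3ccccc3C(C)(C)C)cc2)CC1`, which keeps the shared core and differs from compound 2 in one place: 1-isobutylpiperidin-4-yl in place of 1-((dimethylamino)methyl)-1-methylethyl on a saturated chain carbon bound to an oxygen on an aromatic ring is the whole change. Here 1-isobutylpiperidin-4-yl stands in place of 1-((dimethylamino)methyl)-1-methylethyl on a saturated chain carbon bound to an oxygen on an aromatic ring, and neither group carries a net charge.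

Among the compounds with values here, only one measured step bears on this change: a number 0.50 log units higher from compound 1 to compound 2 (beyond the scatter) was modest and beyond the scatter, and it led to the group that now leaves. Within the data shown here, no measured compound carries the entering group, so the support is thin. With the larger group entering, and going by the size of that one step, a modest rise is expected rather than a fall. The expected change is a number 0.50 log units higher from compound 2 to compound 3 (beyond the scatter) on this estimate. In this assay compound 3 is estimated at 5.6 with 5.1 to 6.2 as the expected range.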

Compound 3, partition coefficient: 4.5
For compound 3 the middle estimate is 1.10 log units above the measured one; the measured number lies below the stated range.
By their numbers in this assay, from the lowest: compounds 3 and 1 (each within the scatter of the next); then compound 2.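

Working notes, side chain on the saturated chain carbon bound to an oxygen on an aromatic ring. In this assay the exchange gives a number 0.60 log units lower from compound 2 to compound 3 (beyond the scatter), so the group with more heavy atoms, 1-isobutylpiperidin-4-yl, stands on the lower side of 1-((dimethylamino)methyl)-1-methylethyl, although the printed counts of hydrogen-bond donors, acceptors and nitrogen atoms match and neither group carries a net charge. Measured against the other side chain, the result is a number 0.10 log units lower from compound 1 to compound 3 (within the scatter), so (1-isobutylpiperidin-4-yl)methoxy and 1-(hydroxymethyl)cyclopropyl cannot be told apart on this read-out, and compound 2 alone stands clear of the other two. No measurement at hand accounts for the step between the two amine side chains.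

The change replaces an open chain with a six-membered ring and also brings in the isobutyl group, so these compounds leave open which of the two parts goes with the lower number. A 1-methylpiperidin-4-yl group or a morpholine ring on the same chain carbon would help separate the contribution of the ring from that of the isobutyl group.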